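Indole-bipyridyl series: alkylation of the indole nitrogen

This account rests on a few compounds, and the source may have more. Where it says the series, first, only, none or still open, it means among the compounds named here.

Compound 1 `Oc1ccc2[nH]c(-c3cncc(-c4cc5cc(O)ccc5[nH]4)c3)cc2c1` is the parent with free aromatic nitrogens; in a functional assay on CCRF-CEM cells (Homo sapiens) for cytotoxicity (a lower number here means a stronger inhibitor, a higher number a weaker inhibitor), compound 1 gives 7990 nM. Compound 2 `CN(C)CCn1c(-c2cncc(-c3cc4cc(O)ccc4[nH]3)c2)cc2cc(O)ccc21` carries 2-(dimethylamino)ethyl in place of hydrogen on an aromatic nitrogen; in this assay compound 2 gives 5760 nM. The step is a 1.4-fold lower number from compound 1 to compound 2 (0.14 log units; within the scatter), so the two values cannot be told apart.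

Compound 3 `CN(C)CCCOc1ccc(-c2cncc(-c3cc4ccccc4[nH]3)c2)cc1` belongs to a different core; how the core of compound 3 differs from the core of compound 1 is not broken down here. In this assay compound 3 gives 5400 nM, which sits within the scatter of both compound 1 and compound 2.

Compound 4 `CN(C)CCCOc1ccc(-c2cncc(-c3cc4ccccc4n3CCN(C)C)c2)cc1` is not yet measured. It differs from compound 3 by 2-(dimethylamino)ethyl in place of hydrogen on an aromatic nitrogen. The description of the place matches word for word the place of the change from compound 1 to compound 2, so this is the same change made on the other core.

Expected step in this assay is a 1.3-fold lower number from compound 3 to compound 4 (0.11 log units; within the scatter), placed beside the earlier one; the expectation rests on a 1.4-fold lower number from compound 1 to compound 2 (0.14 log units; within the scatter), which was flat, and on the single precedent only. Compound 4 is therefore estimated at 4200 nM, with a range from 1500 nM to 12000 nM.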

Compound 4, half-maximal inhibitory concentration: 3720 nM
Compound 4: middle estimate off by 1.1-fold (0.05 log units), on the high side, within the range that was stated.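

In this assay, 2-(dimethylamino)ethyl in place of hydrogen on an aromatic nitrogen gives a 1.5-fold lower number from compound 3 to compound 4 (0.16 log units; within the scatter), so on the core of compound 3 the change cannot be told from no change at all. Set beside the earlier step, the change reads the same on both cores: the same change on two cores in this assay, a 1.4-fold lower number (0.14 log units; within the scatter) from compound 1 to compound 2 and a 1.5-fold lower number (0.16 log units; within the scatter) from compound 3 to compound 4, 1.0-fold (0.02 log units) apart, within the scatter of two such steps. This shows that the change stays flat on the two cores shown and in this one read-out, but it does not show that the group lowers the number, and two flat steps cannot say how the change would behave on any further core.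

On these data alone, it remains open whether a longer chain ending in the same dimethylamino group, a primary amine or a carboxylic acid in place of the 2-(dimethylamino)ethyl would give a step beyond the scatter. As far as these compounds go, it is also open whether a second 2-(dimethylamino)ethyl, on the remaining aromatic nitrogen of compound 2, would leave the number flat.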